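The source may report more compounds than this note shows. Statements on the series, on what has been measured and on what is new or still open speak of the compounds shown alone.

Measured in a functional assay on Jurkat cells (Homo sapiens); on this read-out higher numbers stand for weaker inhibition and lower numbers for stronger inhibition:
compound 1 `CC(C)[C@H](NC(=O)COc1cccc2ccccc12)C(=O)N[C@@H](CC(=O)O)C(=O)COC(=O)c1c(Cl)cccc1Cl` gives 10600 nM
compound 2 `CC(C)[C@H](NC(=O)COc1cccc2ccccc12)C(=O)N[C@@H](CC(=O)O)C(=O)COc1ccccc1` gives 14000 nM
compound 3 `CC(C)[C@H](NC(=O)COc1cccc2ccccc12)C(=O)N[C@@H](CC(=O)O)C(=O)COc1ccc(-c2ccccc2)cc1` gives 87900 nM

Compound 1 stands level with compound 2 (a 1.3-fold higher number from compound 1 to compound 2 (0.12 log units; within the scatter)) and clear of compound 3 (an 8.3-fold higher number from compound 1 to compound 3 (0.92 log units; beyond the scatter)) at the stronger end of the three.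

Compound 4 `CC(C)[C@H](NC(=O)COc1cccc2ccccc12)C(=O)N[C@@H](CC(=O)O)C(=O)COc1ccccc1C(F)(F)F` has not yet been measured. Its change (2-(trifluoromethyl)phenyl in place of (2,6-dichlorophenyl)carbonyl on an oxygen on a saturated carbon) puts 2-(trifluoromethyl)phenyl in place of (2,6-dichlorophenyl)carbonyl on an oxygen on a saturated carbon.

The closest guide is the swap to plain phenyl at that same place (a 1.3-fold higher number from compound 1 to compound 2 (0.12 log units; within the scatter)), which stayed within the scatter. Compound 4 carries that ring with a trifluoromethyl added. Adding phenyl to the ring of compound 2 gave a modest rise (a 6.3-fold higher number from compound 2 to compound 3 (0.80 log units; beyond the scatter)), but that is a different group. A slight upward lean is therefore expected in this assay, with no step beyond the scatter.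

The expected step is small (a 1.5-fold higher number from compound 1 to compound 4 (0.18 log units; within the scatter)) on this estimate. Compound 4 is expected at 16000 nM within an estimated range from 6000 nM to 40000 nM on this read-out.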

Compound 4, half-maximal inhibitory concentration: > 100000 nM
Compound 4: only a limit was reported; the forecaster's own chance of this, stated with the estimate: 5%; middle value at least 6.2-fold (0.79 log units) away from the limit.
By their numbers in this assay, from the lowest: compounds 1 and 2 (each within the scatter of the next); then compound 3. At a limit, above all of these: compound 4.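

Compound 4 gives > 100000 nM in this assay, which is a limit of the assay and not a number. Plain phenyl had stayed level with the (2,6-dichlorophenyl)carbonyl group, so this place looked forgiving, yet adding one trifluoromethyl to that ring gives an at least 7.1-fold higher number from compound 2 to compound 4 (0.85 log units; beyond the scatter), and the full swap gives an at least 9.4-fold higher number from compound 1 to compound 4 (0.97 log units; beyond the scatter). Until now only the 4-phenylphenyl group had shown a rise beyond the scatter here, and the further step, an at least 1.1-fold higher number from compound 3 to compound 4 (0.05 log units; that floor lies within the scatter), has a floor within the scatter, so it establishes no real gap between those two.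

As far as these compounds go, how far the true value of compound 4 lies past the limit stays unknown. Also open, from the compounds shown here alone, is whether a methyl, a methoxy or an amine in place of the trifluoromethyl would keep the number close to that of compound 2.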